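Cyclopropylpiperazine in place of piperidine: stability expectation

The source may hold more compounds than are shown below. What is called first, only, known or untested is meant among the compounds shown, and "the series" means these compounds.

Compound 1 `c1ccc2c(c1)CN[C@@H](CN(CC[C@H]1CCCNC1)[C@H]1CCCc3cccnc31)C2` is measured in an ADME assay on microsomes from liver (Rattus norvegicus) for metabolic stability, read by LC-MS, with a stated time of 10 min, tested at 0.5 uM (on this read-out lower numbers stand for a less stable compound and higher numbers for a more stable compound), and gives 55%. This is the lower of the two numbers recorded so far. Compound 2 `c1ccc2c(c1)CN[C@H](CN(CCCN1CCNCC1)[C@H]1CCCc3cccnc31)C2` is the nearest comparator; in this assay compound 2 gives 88%, a gap to compound 1 that lies beyond the usual scatter. Going by the values given here, no step between compounds that differ in a single place is available, so the two values only show that compound 2 sits well above compound 1 on this read-out.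

Compound 3 `c1ccc2c(c1)CN[C@@H](CN(CCCN1CCN(C3CC3)CC1)[C@H]1CCCc3cccnc31)C2` has not yet been measured in this assay. Its structure differs from compound 1 as follows: (4-cyclopropylpiperazin-1-yl)methyl in place of piperidin-3-yl on a saturated chain carbon, two bonds along the chain from an amine nitrogen. Compound 3 shares with compound 2 a piperazine on a chain from the amine nitrogen, which compound 1 lacks, and compound 2 gives 88% while compound 1 gives 55%.

For compound 3 an upward step is expected, a number 17 percentage points higher from compound 1 to compound 3 (beyond the scatter), of a size beyond the scatter, because compound 2 with its related chain gives 88%. The estimated value for compound 3 in this assay is 72%, with a range from 48% to 92%.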

Compound 3, percent of the compound remaining: 2%
For compound 3 the middle estimate is 70 percentage points above the measured one; measured number outside the range, below it.
By their numbers in this assay, from the lowest: compound 3; then compound 1; then compound 2.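

In this assay, going by these compounds alone, putting (4-cyclopropylpiperazin-1-yl)methyl in place of piperidin-3-yl on a saturated chain carbon, two bonds along the chain from an amine nitrogen, gives a number 53 percentage points lower from compound 1 to compound 3 (beyond the scatter) and so supplies the first single-place step. This position is therefore not indifferent to the group it carries: with the core of compound 1 held constant, this one exchange moves the read-out by a large amount, and compound 3 gives 2% in this comparison. The exchange alters several features at once, with a three-membered carbon ring and a six-membered ring with 2 hetero atoms entering, and nothing measured here gives a reason for the step or assigns it to either feature.

Still open, on these data alone, is whether the step follows the cyclopropyl group or the piperazine with its chain, as this single pair changes both together. A compound with (4-methylpiperazin-1-yl)methyl or (piperazin-1-yl)methyl at the same place, on the same core, would divide the step between those two parts.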